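This account rests on a few compounds, and the source may have more. Where it says the series, first, only, none or still open, it means among the compounds named here.

Measured compounds:
- compound 1 `Cc1nc(C)c(S(=O)(=O)NC(=O)NC/C=C2\CCCc3cnn(Cc4ccc(Cl)cc4Cl)c32)s1`: 2 nM
- compound 2 `COc1ccc(S(=O)(=O)NC(=O)NC/C=C2\CCCc3cnn(Cc4ccc(Cl)cc4Cl)c32)cc1`: 10 nM

Going by the values given here, in an assay on isolated protein for displacement of a labelled ligand from prostaglandin E2 receptor EP3 subtype (Homo sapiens), read by scintillation counting, with a stated time of 2 h (on this read-out lower numbers stand for stronger inhibition and higher numbers for weaker inhibition), compound 2 gives the highest of the two numbers; the only neighbour is compound 1, at a 5.0-fold higher number from compound 1 to compound 2 (0.70 log units; beyond the scatter). Compound 3 `COc1ccccc1S(=O)(=O)NC(=O)NC/C=C1\CCCc2cnn(Cc3ccc(Cl)cc3Cl)c21` carries the same atoms joined differently: 2-methoxyphenyl in place of 4-methoxyphenyl on a sulfonyl sulfur. Among the compounds with values here, no measured step moves a methoxy group about its ring; the single step, from the thiazolyl to the methoxyphenyl group, changes the whole aryl and bears on this only loosely. The change is therefore expected to stay small, a 1.5-fold higher number from compound 2 to compound 3 (0.18 log units; within the scatter), with wide uncertainty. For compound 3 the estimate in this assay is 15 nM, within 4 nM to 60 nM.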

Compound 3, inhibition constant: 62 nM
Estimate against measurement, compound 3: 4.1-fold (0.62 log units) below; measured number outside the range, above it.
By their numbers in this assay, from the lowest: compound 1; then compound 2; then compound 3.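

In this assay the place of the methoxy group on the phenyl ring matters, since 2-methoxyphenyl in place of 4-methoxyphenyl gives a 6.2-fold higher number from compound 2 to compound 3 (0.79 log units; beyond the scatter) with the same atoms. Replacing the 2,4-dimethyl-1,3-thiazol-5-yl group gives the larger 31-fold higher number from compound 1 to compound 3 (1.49 log units; beyond the scatter), so this sulfonyl substituent is sensitive to both the choice of aryl group and the arrangement of its methoxy group. No available evidence accounts for these shifts.

Going by these compounds, how an amine or a carboxylic acid in place of the methoxy group would read in this assay remains open.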